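A few compounds are considered here, and "the series" means these few. Any claim that something is new, unique, unknown or untested is made for them only; others in the source may bear on it.

Working notes on the series. In an ADME assay for solubility, in simulated intestinal fluid (a higher number here means a more soluble compound, a lower number a less soluble compound), compound 1 (`O=C(O)c1cccn1-c1ccc2c(c1)B(O)OC2`) gives > 1000 ug/mL, which is a limit of the assay and not a number. Compound 2 (`OB1OCc2ccc(Oc3nnn[nH]3)cc21`) gives > 1000 ug/mL, again a limit and not a number. Among the measured compounds shown here, both values shown sit at the same limit, (the limit of > 1000 ug/mL in this assay, at which 2 of the 2 values shown sit), so compound 2 has no exact position and no step between measured compounds is available.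

Compound 3 (`OB1OCc2ccc(Oc3nnn[nH]3)c(F)c21`) carries one change from compound 2, fluoro in place of hydrogen on an aromatic carbon, ortho to a fused ring and ortho to a group of 6 heavy atoms. In this assay, no shift beyond the usual scatter is expected, and any small move would more likely be downward. The expected step is a number no higher from compound 2 to compound 3 (the limit leaves the size open). For compound 3 the estimate is 1000 ug/mL, with an expected range of 400 ug/mL to 2000 ug/mL.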

Compound 3, solubility: > 1000 ug/mL
Compound 3 ended at the assay's limit; the forecaster's own chance of this, stated with the estimate: 60%; the middle value lies on the limit itself.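

In this assay compound 3 gives > 1000 ug/mL, a limit and not a number. With compound 2 at the same limit, no step can be read between compound 2 and compound 3: the limit of > 1000 ug/mL in this assay, at which 3 of the 3 values shown sit.

The compounds shown leave open how the three rank, and what fluoro in place of hydrogen on an aromatic carbon does to the read-out.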